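This account rests on a few compounds, and the source may have more. Where it says the series, first, only, none or still open, it means among the compounds named here.

Compounds measured in an assay (strain Wistar) for inhibition of Hormone-sensitive lipase (Rattus norvegicus), read by spectrophotometry; a higher number here means a weaker inhibitor, a lower number a stronger inhibitor:

Compound 1, `Cc1c(C(C)C)c(=O)on1C(=O)N(C)CC(N)=O`, reaches in this assay only the limit of > 1000 nM, which is not a number.
Compound 2, `Cc1c(C(C)C)c(=O)on1C(=O)N1CCC(Cc2ccccc2)CC1`, gives in this assay 102 nM.
Compound 3, `COCCc1c(C)n(C(=O)N2CCC(c3ccccc3)CC2)oc1=O`, gives in this assay 11 nM.

Among the two numerical values, compound 2 has the higher number; compound 3 sits at a lower number, and that gap lies beyond the usual scatter. Compound 1, whose ring nitrogen carries a small amide chain rather than a saturated ring, sits at the limit of the assay (the limit of > 1000 nM in this assay, at which 1 of the 3 values shown sits).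

Compound 4, `Cc1c(C(C)C)c(=O)on1C(=O)N1CCC(C(=O)N(C)C)CC1`, is compound 2 with one change: dimethylcarbamoyl in place of benzyl on a saturated ring carbon. An aromatic ring is exchanged for a small carbonyl-bearing group on the saturated ring. No measured pair shows such an exchange, so the expectation rests on what is shown: the two saturated-ring compounds carrying an aromatic ring reach the lower numbers, while the one compound without such a ring, compound 1, stops at the limit. Compound 4 is therefore expected to move toward a higher number, a step of a 5.9-fold higher number from compound 2 to compound 4 (0.77 log units; beyond the scatter) that goes beyond the scatter. Compound 4 is estimated at 600 nM, with a range from 150 nM to 3000 nM.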

Compound 4, half-maximal inhibitory concentration: > 1000 nM
Compound 4 ended at the assay's limit (the forecaster's own chance of this, stated with the estimate: 30%); middle value at least 1.6-fold (0.22 log units) away from the limit.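

In this assay compound 4 gives > 1000 nM, which is a limit of the assay and not a number. Among the compounds shown here, the exchange of benzyl for dimethylcarbamoyl on this saturated ring carbon, three ring bonds from the ring nitrogen, is the one change here that can be read at a single place, and it gives an at least 9.8-fold higher number from compound 2 to compound 4 (0.99 log units; beyond the scatter), so what this ring carbon carries matters. Compound 4 thereby joins compound 1 at the limit: the limit of > 1000 nM in this assay, at which 2 of the 4 values shown sit.

The compounds shown leave open whether the step follows from the loss of the aromatic ring or from the arrival of the carbonyl, which a cyclohexylmethyl group on the same ring carbon would help to separate. They also leave open how a longer chain ending in a dimethylamino group or a carboxylic acid would read at this place, and the full size of the step, which the limit does not give.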